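Methoxy for fluoro on a shared core

A few compounds are considered here, and "the series" means these few. Any claim that something is new, unique, unknown or untested is made for them only; others in the source may bear on it.

Measured so far:
compound 1 `CC(=O)c1cc(-c2ccccc2)cc2cc(-c3ccccc3)[nH]c12` gives > 100000 nM in a functional assay on MCF7 cells (Homo sapiens) for cytotoxicity, read by MTT assay, with a stated time of 2 days; a lower number here means that less compound is tolerated, a higher number that more compound is tolerated
compound 2 `CC(=O)c1cc(-c2ccccc2)cc2cc(-c3ccc(F)cc3)[nH]c12` gives > 100000 nM in this assay
compound 3 `COc1ccc(-c2cc(C(C)=O)c3[nH]c(-c4ccc(F)cc4)cc3c2)cc1` gives 16800 nM in this assay

Compound 2 stands at a limit of this assay rather than at a number, and that same limit is where compound 1 also sits (the limit of > 100000 nM in this assay, at which 2 of the 3 values shown sit). Compound 3 is the only one of the three with a number.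

Compound 4 `COc1ccc(-c2cc3cc(-c4ccccc4)cc(C(C)=O)c3[nH]2)cc1` differs from compound 2 in one place: methoxy in place of fluoro on an aromatic carbon. Within the data shown here, two measured steps bear on it. The step that the two limits leave unreadable from compound 1 to compound 2 is unreadable because both ends are limits. The step of an at least 5.9-fold lower number from compound 2 to compound 3 (0.77 log units; beyond the scatter) shows that a methoxy entering on an aromatic carbon brought the number down from the limit to a readable value, though on a different ring of the core than the change here. On that basis, compound 4 is expected to fall below the limit where compound 2 stands, by a step of an at least 2.5-fold lower number from compound 2 to compound 4 (0.39 log units; beyond the scatter). Compound 4 is therefore estimated at 40000 nM, within a range of 12000 nM to 150000 nM, with a real chance that only a limit is reported.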

Compound 4, concentration lethal to 50% of the cells: > 100000 nM
Compound 4: no number, only a limit; the forecaster's own chance of this, stated with the estimate: 30%; middle value at least 2.5-fold (0.39 log units) away from the limit.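

Compound 4 also stands at a limit and not at a number, so no new step can be read from compound 1 or compound 2 to it: the limit of > 100000 nM in this assay, at which 3 of the 4 values shown sit. The compounds shown leave open whether going from 4-fluorophenyl to 4-methoxyphenyl changes the number at all in this assay.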